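The source may hold more compounds than are shown below. What is called first, only, known or untested is meant among the compounds shown, and "the series" means these compounds.

Going by the values given here, compound 3 `Cc1nn(-c2nc(-c3ccc(Cl)c(Cl)c3)c(SC(C)C)s2)c(C(=O)O)c1-c1ccccc1Cl` is one of three compounds measured in a functional assay on BJAB cells (Homo sapiens) for antiproliferative activity, with a stated time of 4 days (on this read-out higher numbers stand for an effect only at larger amounts of compound and lower numbers for an effect already at smaller amounts), where compound 3 gives 13100 nM. On the numbers in hand compound 3 stands second highest of the three: its nearest neighbour is compound 2 `Cc1cccc(-c2c(C)nn(-c3nc(-c4ccc(Cl)c(Cl)c4)c(SC(C)C)s3)c2C(=O)O)c1`, for which this assay gives 17000 nM, and the step of a 1.3-fold lower number from compound 2 to compound 3 (0.11 log units; within the scatter) lies within the scatter. The furthest is compound 1 `Cc1cc(Cl)cc(-c2c(C)nn(-c3nc(-c4ccc(Cl)c(Cl)c4)c(SC(C)C)s3)c2C(=O)O)c1`, which in this assay gives 663 nM; the step of a 20-fold higher number from compound 1 to compound 3 (1.30 log units; beyond the scatter) is large, as is a 26-fold higher number from compound 1 to compound 2 (1.41 log units; beyond the scatter).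

Compound 4 `CC(=O)Nc1ccc(-c2c(C)nn(-c3nc(-c4ccc(Cl)c(Cl)c4)c(SC(C)C)s3)c2C(=O)O)cc1` is not yet measured. It differs from compound 3 at the same position that the measured steps concern: 4-acetamidophenyl in place of 2-chlorophenyl on an aromatic carbon. Among the compounds with values here, both measured steps at this position, a 20-fold higher number from compound 1 to compound 3 (1.30 log units; beyond the scatter) and a 1.3-fold lower number from compound 2 to compound 3 (0.11 log units; within the scatter), involve 2-chlorophenyl, 3-methylphenyl or 3-chloro-5-methylphenyl; none involves 4-acetamidophenyl, so no measured step speaks directly to the group that enters. Within the data shown here, the data show only that compound 1 is set apart from compounds 2 and 3 by steps beyond the scatter, while compounds 2 and 3 lie within the scatter of each other. The step of a 1.5-fold lower number from compound 3 to compound 4 (0.16 log units; within the scatter) is therefore expected to be uncertain in direction and small. Compound 4 is expected to give about 9000 nM in this assay, within a range from 1500 nM to 40000 nM.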

Compound 4, half-maximal effective concentration: 139000 nM
Compound 4: middle estimate off by 15-fold (1.19 log units), on the low side, outside the stated range (above it).
By their numbers in this assay, from the lowest: compound 1; then compounds 3 and 2 (each within the scatter of the next); then compound 4.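

In this assay, going by these compounds alone, the earlier compounds showed only that 3-chloro-5-methylphenyl stood apart from 2-chlorophenyl and 3-methylphenyl, which lay within the scatter of each other. The 4-acetamidophenyl group now shows that the numbers at this position reach well beyond that pair, with an 11-fold higher number from compound 3 to compound 4 (1.03 log units; beyond the scatter) and an 8.2-fold higher number from compound 2 to compound 4 (0.91 log units; beyond the scatter), so the two no longer mark the high end of what a change on this aromatic carbon can give. The full span among the groups at this position widens to a 210-fold higher number from compound 1 to compound 4 (2.32 log units; beyond the scatter), larger than any earlier step, and no measurement given here bears on the reason for this rise.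

On these data alone, whether the higher number follows the whole acetamido group or only part of it stays open, and a plain amine or a longer acyl chain in its stead on the phenyl ring would separate the two. As far as these compounds go, it also stays open whether a carboxylic acid or a methoxy group on that ring would give a number near that of compound 4 or nearer that of compound 1.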